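The source may report more compounds than this note shows. Statements on the series, on what has been measured and on what is new or still open speak of the compounds shown alone.

Working notes on a dienone series. Compound 1 `CC1=C(/C=C/C(=O)/C=C/c2ccccc2Br)C(C)(C)CCC1` and compound 2 `CC1=C(/C=C/C(=O)/C=C/C=C/c2ccccc2)C(C)(C)CCC1` share a core and differ in the aryl part of the chain. In a functional assay on MCF7 cells (Homo sapiens) for cytotoxicity, read by sulforhodamine B assay, with a stated time of 48 h (on this read-out higher numbers stand for weaker inhibition and lower numbers for stronger inhibition), compound 1 gives 20700 nM. In this assay compound 2 gives 46700 nM, the highest of the two numbers, and its nearest neighbour is compound 1, whose number is lower by more than the usual scatter. The two compounds differ in more than one place, so the two values are noted as they stand and no single change is read from them.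

Compound 3 `COc1ccccc1/C=C/C=C/C(=O)/C=C/C1=C(C)CCCC1(C)C` follows from compound 2 by one change: methoxy in place of hydrogen on an aromatic carbon. Among the measured compounds shown here, no measured pair shows this change anywhere, so nothing here tells its size or direction. The expectation is a step of a 1.2-fold lower number from compound 2 to compound 3 (0.09 log units; within the scatter), which is within the scatter rather than a real shift. Compound 3 is therefore estimated at 38000 nM in this assay, with a range from 15000 nM to 90000 nM.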

Compound 3, half-maximal inhibitory concentration: 55400 nM
For compound 3 the middle estimate is 1.5-fold (0.16 log units) below the measured one; measured number inside the range.
By their numbers in this assay, from the lowest: compound 1; then compounds 2 and 3 (each within the scatter of the next).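

The change from phenyl to 2-methoxyphenyl now has its first measured pair in the series, and in this assay it gives a 1.2-fold higher number from compound 2 to compound 3 (0.07 log units; within the scatter) and so does not separate compound 3 from compound 2. On this aromatic carbon, ortho to a large group, a methoxy with its 2 heavy atoms and 1 hydrogen-bond acceptor therefore leaves the read-out where hydrogen left it, as far as this one pair can tell. No measurement at hand bears on why the read-out stays within the scatter here.

One pair at one place leaves open how another group on this aromatic carbon, such as an amine, a carboxylic acid or a longer chain like butoxy, would read in this assay and whether any of them would step beyond the scatter. Among the compounds shown here, whether methoxy in place of hydrogen would read the same way on the shorter chain of compound 1 also stays open, as the change is seen only on the chain of compound 2.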